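The source may report more compounds than this note shows. Statements on the series, on what has been measured and on what is new or still open speak of the compounds shown alone.

In an ADME assay on the whole organism (Rattus norvegicus, strain Sprague-Dawley) for pharmacokinetics, read by LC-MS, with a stated time of 24 h, at a dose of 1 mg/kg by the intravenous route (a higher number here means that more of the compound sits outside the plasma, a lower number that more of the compound stays in the plasma), compound 1 (`CCN1C(=O)COc2c(CN3CCN(C(C)=O)CC3)cc(Nc3ncc(F)c(-c4ccc(F)cc4OC)n3)cc21`) gives 0.922 L/kg and compound 2 (`CCN1C(=O)COc2c(CN3CCN(S(C)(=O)=O)CC3)cc(Nc3ncc(F)c(-c4ccc(F)cc4OC)n3)cc21`) gives 1.01 L/kg so the two stand level within the scatter. Compound 3 (`CCN(CC)Cc1cc(Nc2ncc(F)c(-c3ccc(F)cc3OC)n2)cc2c1OCC(=O)N2CC`) carries diethylamino in place of 4-(methylsulfonyl)piperazin-1-yl on a saturated chain carbon bound to an aromatic carbon. Among the measured compounds shown here, the only measured step (a 1.1-fold higher number from compound 1 to compound 2 (0.04 log units; within the scatter)) swapped a group on an amine nitrogen in a ring and kept that ring, so it bears only loosely on a change that removes the ring. The step expected in this assay is larger than that one and towards a higher number (a 4.0-fold higher number from compound 2 to compound 3 (0.60 log units; beyond the scatter)). Compound 3 is estimated at 4 L/kg (expected range 1.5 L/kg to 10 L/kg).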

Compound 3, volume of distribution at steady state: 6.45 L/kg
Beside the measured number, compound 3's estimate is 1.6-fold (0.21 log units) below it, and the stated range covers the measured number.
By their numbers in this assay, from the lowest: compounds 1 and 2 (each within the scatter of the next); then compound 3.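

In this assay, the change on this saturated chain carbon moves the read-out beyond the scatter (a 6.4-fold higher number from compound 2 to compound 3 (0.81 log units; beyond the scatter); a 7.0-fold higher number from compound 1 to compound 3 (0.84 log units; beyond the scatter)), whereas swapping acetyl for methylsulfonyl on the ring nitrogen did not (a 1.1-fold higher number from compound 1 to compound 2 (0.04 log units; within the scatter)). At this position, the number therefore responds to replacing the whole piperazine group with diethylamino, not to the tested exchange on its far nitrogen. No available evidence accounts for the shift.

As far as these compounds go, whether it follows from losing the ring or from losing the acyl or sulfonyl group remains open. A piperidin-1-yl or morpholin-4-yl group on the same carbon would separate these two readings.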